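Selenium to sulfur on the shared core

A few compounds are considered here, and "the series" means these few. Any claim that something is new, unique, unknown or untested is made for them only; others in the source may bear on it.

Compound 1 `C[Se]/C(=N\C(=O)c1cc2ccccc2s1)NC(=O)c1cc2ccccc2s1` and compound 2 `C[Se]/C(=N\C(=O)c1ccco1)NC(=O)c1ccco1` have both been run in a functional assay on MCF7 cells (Homo sapiens) for cytotoxicity, read by MTT assay, with a stated time of 72 h; on this read-out lower numbers stand for stronger inhibition of growth and higher numbers for weaker inhibition of growth. In this assay compound 1 gives 32700 nM, the lower of the two numbers, while compound 2 gives 88900 nM, a higher number that lies beyond the scatter. Compound 3 `CS/C(=N\C(=O)c1cc2ccccc2s1)NC(=O)c1cc2ccccc2s1` is not yet measured. It differs from compound 1 by a group of 2 heavy atoms (1 carbon, 1 sulfur; no ring) in place of a group of 2 heavy atoms (1 carbon, 1 selenium; no ring), on a carbon with a double bond to nitrogen. Going by the values given here, no step of this kind is known. A small step toward weaker inhibition is expected, a 1.8-fold higher number from compound 1 to compound 3 (0.26 log units; within the scatter). For compound 3 the estimate in this assay is 60000 nM, with a range of 25000 nM to 150000 nM.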

Compound 3, concentration for total growth inhibition: 43400 nM
Compound 3: the middle estimate sits 1.4-fold (0.14 log units) above what was measured, within the range that was stated.
By their numbers in this assay, from the lowest: compounds 1 and 3 (each within the scatter of the next); then compound 2.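

In this assay the exchange of the selenium-bearing group for methylsulfanyl gives a 1.3-fold higher number from compound 1 to compound 3 (0.12 log units; within the scatter) on a carbon with a double bond to nitrogen. Going by these compounds alone, this is the first step read at this position, and it gives no sign that selenium is required for the growth inhibition seen with compound 1. No evidence on hand accounts for this result. On these data alone, a longer chain such as ethylsulfanyl, or an amine, on that carbon remains open. Also open, as far as these compounds go, is whether the same exchange on compound 2 would stay within the scatter.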